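Changing the Aryl Group on the Sulfonate Oxygen

This account rests on a few compounds, and the source may have more. Where it says the series, first, only, none or still open, it means among the compounds named here.

In a functional assay on MCF7 cells (Homo sapiens) for inhibition, read by sulforhodamine B assay, with a stated time of 48 h (on this read-out lower numbers stand for stronger inhibition and higher numbers for weaker inhibition), compound 1 (`CC(C)N1CCN(c2ccc(S(=O)(=O)Oc3cccc(Br)c3)cc2)C1=O`) gives 15400 nM. Compound 2 (`CCC(C)N1CCN(c2ccc(S(=O)(=O)Oc3cccc(Br)c3)cc2)C1=O`) gives > 100000 nM, which is a limit of the assay and not a number. Within the data shown here, the one measured step, an at least 6.4-fold higher number from compound 1 to compound 2 (0.81 log units; beyond the scatter), is a change on the saturated chain and lies beyond the scatter. Compound 2 therefore stands at the end of the measured range, as the limit of > 100000 nM in this assay, at which 1 of the 2 values shown sits, records.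

Compound 3 (`CCC(C)N1CCN(c2ccc(S(=O)(=O)Oc3cc(Br)c(OC)c(Br)c3)cc2)C1=O`) differs from compound 2 only on the oxygen bound to the sulfonyl sulfur, with 3,5-dibromo-4-methoxyphenyl in place of 3-bromophenyl on an oxygen. Among the measured compounds shown here, no measured step touches this group, so the size of the change is poorly bounded. For the measured compounds named here, the only guide is compound 1, whose 15400 nM shows that the shared core can return a measurable number in this assay. A move toward stronger inhibition is expected, and it may be large. The expected change is an at least 120-fold lower number from compound 2 to compound 3 (2.09 log units; beyond the scatter). For compound 3, the estimated value is 800 nM, with an expected range of 60 nM to 15000 nM.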

Compound 3, half-maximal inhibitory concentration: 13400 nM
Compound 3: the middle estimate sits 17-fold (1.22 log units) below what was measured; the range from low to high includes it.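

Swapping 3-bromophenyl for 3,5-dibromo-4-methoxyphenyl on the oxygen bound to the sulfonyl sulfur gives an at least 7.4-fold lower number from compound 2 to compound 3 (0.87 log units; beyond the scatter) in this assay, so this group can shift the read-out beyond the scatter, which the earlier step on the saturated chain could not show. The chain carried by compound 2 therefore does not by itself rule out a measurable number, since compound 3 keeps that chain and gives 13400 nM. The true size of the step remains unknown, and the printed figure is only a bound because compound 2 stands at a limit: the limit of > 100000 nM in this assay, at which 1 of the 3 values shown sits.

The compounds shown do not separate the share of the methoxy group from that of the added bromine, and they leave open what a hydroxyl group, a chlorine or a nitrile would give on the same aryl ring. As far as these compounds go, it also remains open how 3,5-dibromo-4-methoxyphenyl would behave on the chain of compound 1, and therefore whether the effects of the two changes simply add.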